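Chain shortening in a saturated fatty amide series

The source may report more compounds than this note shows. Statements on the series, on what has been measured and on what is new or still open speak of the compounds shown alone.

Measured compounds:
compound 1 `CCCCCCCCCCCCCCCCCCCC(N)=O`: > 10000 nM in an assay on HEK293 cells for antagonist activity at transient receptor potential cation channel subfamily V member 2 (Rattus norvegicus), read by fluorescence and calcium flux, with a stated time of 5 min; on this read-out higher numbers stand for weaker inhibition and lower numbers for stronger inhibition
compound 2 `CCCCCCCCCCCCCCCCCCCC(=O)NCc1ccc(O)c(OC)c1`: > 10000 nM in this assay

Compound 1 stands at a limit of the assay and not at a number; in this assay compound 1 gives > 10000 nM. Among the measured compounds shown here, the only measured step is a step that the two limits leave unreadable from compound 1 to compound 2, and its size cannot be read because the limit of > 10000 nM in this assay, at which 2 of the 2 values shown sit, leaves no gap to compare. For the measured compounds named here, no measured step touches the saturated chain at all.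

Compound 3 `CCCCCCCCCCCCCCCC(N)=O` differs from compound 1 by hydrogen in place of butyl on a saturated chain carbon, ten or more bonds along the chain from a carbonyl carbon. The step on the amide nitrogen does not bear on this change, and the two measured values give no direction for the chain. The expectation is therefore that compound 3 also sits at the limit, with an estimated step that the limit leaves unreadable from compound 1 to compound 3. Compound 3 is estimated at 15000 nM, within 5000 nM to 50000 nM.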

Compound 3, half-maximal inhibitory concentration: > 10000 nM
Compound 3 ended at the assay's limit (the forecaster's own chance of this, stated with the estimate: 85%); the middle value does not contradict the limit.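

No step can be read between compound 1 and compound 3, as both stand at a limit of the assay and not at a number: the limit of > 10000 nM in this assay, at which 3 of the 3 values shown sit.

The compounds shown leave open whether the length of the saturated chain has any bearing on inhibition.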